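Sulfamoyl for Methoxy on a Weak Antiproliferative Scaffold

The source may report more compounds than this note shows. Statements on the series, on what has been measured and on what is new or still open speak of the compounds shown alone.

Compound 1 `Cc1cccc(-n2nncc2CN2C(=O)C3(C(C#N)=C(N)Oc4c3c3nc5ccccc5nc3c3ccccc43)c3ccccc32)c1` and compound 2 `COc1ccc(-n2nncc2CN2C(=O)C3(C(C#N)=C(N)Oc4c3c3nc5ccccc5nc3c3ccccc43)c3ccccc32)cc1` share one core and differ only in the group on the aromatic nitrogen. In a functional assay on HepG2 cells (Homo sapiens) for antiproliferative activity, read by MTT assay, with a stated time of 48 h (a lower number here means a stronger inhibitor, a higher number a weaker inhibitor), compound 1 gives only the limit > 50000 nM. In this assay compound 2 likewise reaches only the limit > 50000 nM. The step that the two limits leave unreadable from compound 1 to compound 2 thus stays unreadable since (the limit of > 50000 nM in this assay, at which 2 of the 2 values shown sit). Compound 3 `N#CC1=C(N)Oc2c(c3nc4ccccc4nc3c3ccccc23)C12C(=O)N(Cc1cnnn1-c1ccc(S(N)(=O)=O)cc1)c1ccccc12` carries sulfamoyl in place of methoxy on an aromatic carbon. Within the data shown here, no measured step gives a readable size, so the expected step that the limit leaves unreadable from compound 2 to compound 3 is taken as none beyond the scatter. Compound 3 is estimated at 60000 nM, within 20000 nM to 200000 nM, most probably reported once more as a limit.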

Compound 3, half-maximal inhibitory concentration: 42200 nM
For compound 3 the middle estimate is 1.4-fold (0.15 log units) above the measured one; measured number inside the range.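

Among these compounds, with 4-sulfamoylphenyl, compound 3 is the only one of the three to give a number rather than a limit in this assay, so a change at this place can be sized for the first time, though only as a floor. Sulfamoyl in place of methoxy gives an at least 1.1-fold lower number from compound 2 to compound 3 (0.07 log units; that floor lies within the scatter), and the change of the whole aryl group gives an at least 1.1-fold lower number from compound 1 to compound 3 (0.07 log units; that floor lies within the scatter). The true size of both steps stays unknown because the other two compounds end at a limit: the limit of > 50000 nM in this assay, at which 2 of the 3 values shown sit.

The compounds shown leave open whether an amine or a carboxylic acid at this place would separate from compound 3 beyond the scatter.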